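A few compounds are considered here, and "the series" means these few. Any claim that something is new, unique, unknown or untested is made for them only; others in the source may bear on it.

Values in a functional assay on the whole organism for inhibition, with Scenedesmus acutus as the target; a lower number here means a stronger inhibitor, a higher number a weaker inhibitor:
- Compound 1 `O=C(O)c1cc(N2C(=O)C3=C(CCCC3)C2=O)ccc1Cl`: > 100000 nM
- Compound 2 `CCCOC(=O)c1cc(N2C(=O)C3=C(CCCC3)C2=O)c(F)cc1Cl`: 33.1 nM
- Compound 3 `CC(C)OC(=O)c1cc(N2C(=O)C3=C(CCCC3)C2=O)c(F)cc1Cl`: 13.8 nM

Still to be measured: compound 4 `CC(C)(C)OC(=O)c1cc(N2C(=O)C3=C(CCCC3)C2=O)ccc1Cl`.

Compound 1 gives only a limit, > 100000 nM. Compound 4 carries tert-butyl in place of hydrogen on an oxygen next to a carbonyl group, hydroxy to tert-butoxy: tert-butyl in place of hydrogen on an oxygen next to a carbonyl group. Going by the values given here, the one measured step that bears on this is modest: a 2.4-fold lower number from compound 2 to compound 3 (0.38 log units; beyond the scatter), isopropyl in place of propyl. Both of those esters carry a fluorine absent from compound 4, so they guide the estimate only loosely. Even so, compound 3 at 13.8 nM points to a large expected move toward a lower number in this assay. The expected step is an at least 660-fold lower number from compound 1 to compound 4 (2.82 log units; beyond the scatter). For compound 4 the estimate is 150 nM, with an expected range of 20 nM to 1500 nM.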

Compound 4, half-maximal inhibitory concentration: 81300 nM
For compound 4 the middle estimate is 540-fold (2.73 log units) below the measured one; measured number outside the range, above it.
By their numbers in this assay, from the lowest: compound 3; then compound 2; then compound 4. At a limit, above all of these: compound 1.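

In this assay, tert-butyl in place of hydrogen on this oxygen gives an at least 1.2-fold lower number from compound 1 to compound 4 (0.08 log units; that floor lies within the scatter) and so establishes no gain from the tert-butyl ester over the free acid. Compound 1 gives > 100000 nM which is a limit of the assay. The step can be read only as a floor because compound 1 stands at that limit: the limit of > 100000 nM in this assay, at which 1 of the 4 values shown sits.

Open, on these data alone, is how tert-butoxycarbonyl reads out on the fluorine-bearing core of compound 3. Also open, as far as these compounds go, is whether a methyl ester or an amide at this place on the core of compound 4 gives a lower number.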